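Adding Fluoro to the 4-Methylphenyl Group of Compound 3

A few compounds are considered here, and "the series" means these few. Any claim that something is new, unique, unknown or untested is made for them only; others in the source may bear on it.

Values in a functional assay on MGC-803 cells (Homo sapiens) for antiproliferative activity, read by CellTiter-Glo, with a stated time of 72 h; a higher number here means a weaker inhibitor, a lower number a stronger inhibitor:
- compound 1 `Cc1ccc(-c2cc(/C=C/c3ccc(C(=O)NO)cc3)ccn2)cc1`: 1910 nM
- compound 2 `Cc1ccc(-c2cc(/C=C/c3ccc(C(=O)NO)cc3)ccn2)c(F)c1`: 770 nM
- compound 3 `Cc1ccc(-c2cc(/C=C/c3ccc(C(=O)NO)cc3)c(F)cn2)cc1`: > 10000 nM
- compound 4 `Cc1ccc(-c2cc(/C=C/c3ccc(C(=O)NO)cc3)c(F)cn2)c(F)c1`: not yet measured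

Compound 3 gives only a limit of this assay, > 10000 nM. Its fluoro, on a different aromatic carbon from the one changed here, gave an at least 5.2-fold higher number from compound 1 to compound 3 (0.71 log units; beyond the scatter). Compound 4 differs from it by one change: fluoro in place of hydrogen on an aromatic carbon. Among the measured compounds shown here, this is the same 4-methylphenyl to 2-fluoro-4-methylphenyl change that gave a 2.5-fold lower number from compound 1 to compound 2 (0.39 log units; beyond the scatter), the closest precedent. A modest move to a lower number is therefore expected, though compound 4 may also stop at the limit. The expected size is an at least 1.5-fold lower number from compound 3 to compound 4 (0.18 log units; that floor lies within the scatter). For compound 4 the estimate is 6500 nM, with an expected range of 2500 nM to 16000 nM.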

Compound 4, half-maximal inhibitory concentration: 2510 nM
Estimate against measurement, compound 4: 2.6-fold (0.41 log units) above; low and high end bracket the measured number.
By their numbers in this assay, from the lowest: compound 2; then compounds 1 and 4 (each within the scatter of the next). At a limit, above all of these: compound 3.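

In this assay the 4-methylphenyl to 2-fluoro-4-methylphenyl change also lowers the number on the core of compound 3 (an at least 3.9-fold lower number from compound 3 to compound 4 (0.60 log units; beyond the scatter)), so this effect is not confined to the core of compound 1: the same change on two cores in this assay, a 2.5-fold lower number (0.39 log units; beyond the scatter) from compound 1 to compound 2 and an at least 3.9-fold lower number (0.60 log units; beyond the scatter) from compound 3 to compound 4; the limit leaves it open whether they differ.
The fluoro of compound 3 still raises the number when the 2-fluoro-4-methylphenyl group is present (a 3.3-fold higher number from compound 2 to compound 4 (0.51 log units; beyond the scatter)): the same change on two cores in this assay, an at least 5.2-fold higher number (0.71 log units; beyond the scatter) from compound 1 to compound 3 and a 3.3-fold higher number (0.51 log units; beyond the scatter) from compound 2 to compound 4; the limit leaves it open whether they differ.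
Compound 3 stands only at a limit of the assay, > 10000 nM.

The relative size of the two steps for each change cannot be read.
As far as these compounds go, whether chloro, methoxy or an amine at this aromatic carbon would also lower the number remains open.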